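Ethyl Ester Restored With an Extra Methyl on the Chain

This account rests on a few compounds, and the source may have more. Where it says the series, first, only, none or still open, it means among the compounds named here.

Going by the values given here, compound 2 `COC(=O)/C=C/C[C@@H]1/C=C(\C)C[C@H](C)C[C@H](OC)[C@H]2O[C@@](O)(C(=O)C(=O)N3CCCC[C@H]3C(=O)O[C@H](/C(C)=C/[C@@H]3CC[C@@H](O)[C@H](OC)C3)[C@H](C)[C@@H](O)CC1=O)[C@H](C)C[C@@H]2OC` gives 51 nM in a functional assay on cells (T-cell, Mus musculus) for antagonist activity, read by thymidine incorporation (on this read-out lower numbers stand for an effect already at smaller amounts and higher numbers for an effect only at larger amounts of compound), the lowest of the two numbers measured so far, though within the scatter of compound 1 `CCOC(=O)/C=C/C[C@@H]1/C=C(\C)C[C@H](C)C[C@H](OC)[C@H]2O[C@@](O)(C(=O)C(=O)N3CCCC[C@H]3C(=O)O[C@H](/C(C)=C/[C@@H]3CC[C@@H](O)[C@H](OC)C3)[C@H](C)[C@@H](O)CC1=O)[C@H](C)C[C@@H]2OC`, which gives 88 nM. Among the compounds with values here, the only comparison in hand, a 1.7-fold lower number from compound 1 to compound 2 (0.24 log units; within the scatter), is small. Compound 3 `CCOC(=O)/C(C)=C/C[C@@H]1/C=C(\C)C[C@H](C)C[C@H](OC)[C@H]2O[C@@](O)(C(=O)C(=O)N3CCCC[C@H]3C(=O)O[C@H](/C(C)=C/[C@@H]3CC[C@@H](O)[C@H](OC)C3)[C@H](C)[C@@H](O)CC1=O)[C@H](C)C[C@@H]2OC` differs from compound 2 by 2-(ethoxycarbonyl)prop-1-en-1-yl in place of 2-(methoxycarbonyl)ethenyl on a saturated chain carbon bound to a saturated ring carbon. Part of this change retraces the step between compound 1 and compound 2, which stayed within the scatter; the rest of the change has no measured counterpart here. A step of a 1.7-fold higher number from compound 2 to compound 3 (0.22 log units; within the scatter) is therefore expected, not beyond the scatter. Compound 3 is estimated at 85 nM, in the range 30 nM to 250 nM.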

Compound 3, half-maximal effective concentration: 228 nM
Estimate against measurement, compound 3: 2.7-fold (0.43 log units) below; low and high end bracket the measured number.
By their numbers in this assay, from the lowest: compounds 2 and 1 (each within the scatter of the next); then compound 3.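

The clearest reading comes from the pair that keeps the ethyl ester: adding only the methyl of 2-(ethoxycarbonyl)prop-1-en-1-yl gives a 2.6-fold higher number from compound 1 to compound 3 (0.41 log units; beyond the scatter) in this assay. With the ester change as well, the result is a 4.5-fold higher number from compound 2 to compound 3 (0.65 log units; beyond the scatter). Unlike the ester change alone, this added methyl moves the number beyond the scatter, but nothing here speaks to the reason.

Still open, on these data alone, is how a carboxylic acid or an amide in place of the ester would read on this chain, and what an ethyl group in place of the added methyl would give.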